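A few compounds are considered here, and "the series" means these few. Any claim that something is new, unique, unknown or untested is made for them only; others in the source may bear on it.

Measured so far in a physicochemical assay for solubility, in phosphate buffer, with a stated time of 24 h, at pH 7.4, tested at 100 uM (on this read-out higher numbers stand for higher solubility and lower numbers for lower solubility), are three compounds:

- compound 1 `O=C(NCc1ccc(S(=O)(=O)c2ccccc2)cc1)c1cc2cnccc2[nH]1` gives 3000 nM
- compound 2 `O=S(=O)(c1ccccc1)c1ccc(CNS(=O)(=O)N2Cc3ccncc3C2)cc1` gives 3000 nM
- compound 3 `O=C(NCc1ccc(S(=O)(=O)c2cccc(C(F)(F)F)c2)cc1)N1Cc2ccncc2C1` gives 10000 nM

Compound 3 (10000 nM) has the highest number of the three, and its gap to each of the other two lies beyond the usual scatter of repeated measurements. Compound 1 and compound 2 show the same number.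

Next comes compound 4 `CCCn1cc(S(=O)(=O)c2ccc(CNC(=O)N3Cc4ccncc4C3)cc2)cn1`, which has not yet been measured. It carries 1-propyl-1H-pyrazol-4-yl in place of 3-(trifluoromethyl)phenyl on a sulfonyl sulfur. Among the measured compounds shown here, no two measured compounds differ in just one place, so the data give no direct guide to the size of this step. The step expected in this assay is therefore only a tentative estimate of a modest rise (a 2.5-fold higher number from compound 3 to compound 4 (0.40 log units; beyond the scatter)), and the wide range reflects that uncertainty. Compound 4 is estimated at 25000 nM with an expected range from 8000 nM to 80000 nM on this scale.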

Compound 4, solubility: 105000 nM
Compound 4: middle estimate off by 4.2-fold (0.62 log units), on the low side; the whole stated range lies below it.
By their numbers in this assay, from the lowest: compounds 1 and 2 (each within the scatter of the next); then compound 3; then compound 4.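

In this assay, among the compounds shown here, putting 1-propyl-1H-pyrazol-4-yl in place of 3-(trifluoromethyl)phenyl on a sulfonyl sulfur gives an 11-fold higher number from compound 3 to compound 4 (1.02 log units; beyond the scatter), so a single change at this place can move the number by a large amount, something no earlier pair of compounds could show. The change is not a simple one, however: a six-membered aromatic ring of carbon only gives way to a five-membered aromatic ring with 2 hetero atoms, the fluorine atoms leave, and hydrogen-bond acceptors enter, all in one step. Nothing at hand gives a reason for the rise.

From the compounds shown here alone, whether the ring or its propyl chain carries the step stays open, and a methyl group or a carboxylic acid in place of that propyl chain would separate the two. Also open, going by these compounds, is whether the same swap would give a similar step on the core of compound 1 or compound 2.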